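This account rests on a few compounds, and the source may have more. Where it says the series, first, only, none or still open, it means among the compounds named here.

Measured so far:
compound 1 `O=C(O)CCc1ccc(OCc2coc(-c3ccccc3)n2)cc1` — 700 nM
compound 2 `COc1cccc(-c2noc(COc3ccc(CCC(=O)O)cc3)n2)c1` — 2670 nM
compound 3 `COc1cccc(-c2noc(COc3ccc(CCC(=O)O)cc3Cl)n2)c1` — 3000 nM

In a functional assay on CHO cells for agonist activity at Free fatty acid receptor 1 (Homo sapiens), read by FLIPR and calcium flux, in the presence of a further agent that is not named here (on this read-out higher numbers stand for an effect only at larger amounts of compound and lower numbers for an effect already at smaller amounts), compound 1 gives the lowest of the three numbers, and compound 2 stands nearest to it. The difference between the two cores of compound 1 and compound 2 is not broken down here. Compound 3 carries chloro in place of hydrogen on an aromatic carbon relative to compound 2, and the step of a 1.1-fold higher number from compound 2 to compound 3 (0.05 log units; within the scatter) shows no meaningful movement.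

Compound 4 `O=C(O)CCc1ccc(OCc2coc(-c3cccc(Cl)c3)n2)cc1` has not yet been measured in this assay. Against compound 1 it shows (chloro in place of hydrogen on an aromatic carbon). This is the same kind of change as from compound 2 to compound 3, but not the same: in compound 3 the chloro sits ortho to a large group and meta to a 2-carboxyethyl group, whereas in compound 4 it sits meta to a large group, on a different ring of the molecule.

Among the compounds with values here, on the single precedent, the only measured chloro-for-hydrogen step, a 1.1-fold higher number from compound 2 to compound 3 (0.05 log units; within the scatter), lies within the scatter, so a step of similar size is expected here, a 1.1-fold lower number from compound 1 to compound 4 (0.03 log units; within the scatter). For compound 4 the estimated value in this assay is 650 nM, expected to fall between 250 nM and 1700 nM.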

Compound 4, half-maximal effective concentration: 160 nM
For compound 4 the middle estimate is 4.1-fold (0.61 log units) above the measured one; measured number outside the range, below it.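

Exchanging phenyl for 3-chlorophenyl on the core of compound 1 gives a 4.4-fold lower number from compound 1 to compound 4 (0.64 log units; beyond the scatter) in this assay. Set beside the earlier chloro-for-hydrogen step, this shows that the change does not carry over as a fixed increment between these two cores: the same change on two cores in this assay, a 1.1-fold higher number (0.05 log units; within the scatter) from compound 2 to compound 3 and a 4.4-fold lower number (0.64 log units; beyond the scatter) from compound 1 to compound 4, 4.9-fold (0.69 log units) apart, beyond the scatter of two such steps. It does not show that the core alone sets the outcome, as the chloro in compound 3 and the chloro in compound 4 also stand on different rings and in different places, and one step per core gives no general rule for the series.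

Open, from the compounds shown here alone, is whether the lower number of compound 4 is particular to chloro or also appears with fluoro, trifluoromethyl or a nitrile at the same place on the core of compound 1. Also open, going by these compounds, is whether chloro on the other six-membered aromatic ring of compound 1, the ring that carries it in compound 3, would again leave the number in place.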